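Cytotoxicity tolerance from compound 2 to compound 3

The source may report more compounds than this note shows. Statements on the series, on what has been measured and on what is new or still open speak of the compounds shown alone.

Measured so far:
compound 1, `Cc1c(Cc2ccccc2)c(=O)oc2cc(OCC(O)CNc3cc([N+](=O)[O-])ccc3O)ccc12`: > 100000 nM
compound 2, `Cc1cc(=O)oc2cc(OCC(O)CN3CCC(C(N)=O)CC3)ccc12`: > 100000 nM

Of the compounds shown here, two have been tested in an ADME assay on A549 cells (Homo sapiens) for cytotoxicity, read by CellTiter-Glo; a higher number here means that more compound is tolerated, a lower number that less compound is tolerated. Compound 1 carries a benzyl group on its core, `Cc1c(Cc2ccccc2)c(=O)oc2cc(OCC(O)CNc3cc([N+](=O)[O-])ccc3O)ccc12`. In this assay compound 1 reaches only a limit, > 100000 nM, and not a number. Compound 2 lacks that benzyl group, `Cc1cc(=O)oc2cc(OCC(O)CN3CCC(C(N)=O)CC3)ccc12`. Compound 2 likewise gives a limit in this assay, > 100000 nM, and no number. Both values therefore sit at the same place, (the limit of > 100000 nM in this assay, at which 2 of the 2 values shown sit), so compound 2 stands at the limit together with compound 1, and no order between them can be read.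

Compound 3 is `Cc1c(Cc2ccc(OC(F)(F)F)cc2)c(=O)oc2cc(OCC(O)CN3CCC(C(N)=O)CC3)ccc12`. It differs from compound 2 in one place: 4-(trifluoromethoxy)benzyl in place of hydrogen on an aromatic carbon.

Going by the values given here, no measured step between these compounds is available, so the expected size of the step for compound 3 rests only on the two limits. Since compound 1, which also carries a benzyl-type group on the same core, gives > 100000 nM, compound 3 is expected to remain at or near the limit too, with an estimated step of a number no higher from compound 2 to compound 3 (the limit leaves the size open), amounting to no change beyond the scatter. For compound 3 in this assay the estimate is 100000 nM, within a range from 30000 nM to 300000 nM.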

Compound 3, half-maximal cytotoxic concentration: 68200 nM
The estimate for compound 3 lay 1.5-fold (0.17 log units) above the measured number; measured number inside the range.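

In this assay, compound 3 gives a number, 68200 nM. Going by these compounds alone, the earlier compounds gave only limits, so 4-(trifluoromethoxy)benzyl on this aromatic carbon, ortho to a methyl group, yields the first value in the set that can be read as a number. The change gives an at least 1.4-fold lower number from compound 2 to compound 3 (0.16 log units; that floor lies within the scatter), which shows no loss of tolerance that can be told from the scatter, even though the group brings an additional six-membered aromatic ring to this position. The true size of the step stays open, as compound 2 holds only a limit and the step is a floor resting on that limit: the limit of > 100000 nM in this assay, at which 2 of the 3 values shown sit.

The compounds shown leave open whether an unsubstituted benzyl or a 4-methoxybenzyl group at this carbon would give a number or a limit in this assay, and so whether the trifluoromethoxy group or the benzyl group goes with the number seen for compound 3. They also leave open how a smaller group such as ethyl, or an amine or a carboxylic acid on the benzyl ring, would read at this position.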